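This account rests on a few compounds, and the source may have more. Where it says the series, first, only, none or still open, it means among the compounds named here.

Working notes on the series.

All four compounds share one core and differ only in the aryl group on the sulfur. Compound 1 `CC(O)(CSc1ccc(C(F)(F)F)cc1)C(=O)Nc1cccc(S(F)(F)(F)(F)F)c1` carries 4-(trifluoromethyl)phenyl on the sulfur. In a functional assay on DU-145 cells (Homo sapiens) for antiproliferative activity, read by propidium iodide staining, with a stated time of 96 h (a lower number here means a stronger inhibitor, a higher number a weaker inhibitor), compound 1 gives 27200 nM. Compound 2 `CC(O)(CSc1ccccc1C(F)(F)F)C(=O)Nc1cccc(S(F)(F)(F)(F)F)c1` has the same atoms joined differently; the difference between the two cores is 2-(trifluoromethyl)phenyl in place of 4-(trifluoromethyl)phenyl on a sulfur. In this assay compound 2 gives 15800 nM, and the step of a 1.7-fold lower number from compound 1 to compound 2 (0.24 log units; within the scatter) lies within the scatter. Compound 3 `CC(O)(CSc1ccc(OC(F)(F)F)cc1)C(=O)Nc1cccc(S(F)(F)(F)(F)F)c1` differs from compound 1 by trifluoromethoxy in place of trifluoromethyl on an aromatic carbon. In this assay compound 3 gives 24700 nM; the step of a 1.1-fold lower number from compound 1 to compound 3 (0.04 log units; within the scatter) is also within the scatter. Among the measured compounds shown here, no step between compound 2 and compound 3 is worked out here; their two values stand within the scatter of each other.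

Compound 4 `CC(O)(CSc1ccccc1OC(F)(F)F)C(=O)Nc1cccc(S(F)(F)(F)(F)F)c1` is not yet measured. It differs from compound 2 by trifluoromethoxy in place of trifluoromethyl on an aromatic carbon. This is the same kind of change as that from compound 1 to compound 3, not the same change: there the place is para to a large group, here it is ortho to a large group. For the measured compounds named here, on that earlier step, a 1.1-fold lower number from compound 1 to compound 3 (0.04 log units; within the scatter), the expected step from compound 2 to compound 4 is a 1.1-fold lower number from compound 2 to compound 4 (0.04 log units; within the scatter), a small one, resting on the single precedent of compound 1 to compound 3 (a 1.1-fold lower number from compound 1 to compound 3 (0.04 log units; within the scatter)). Compound 4 is therefore estimated at 14500 nM in this assay, with an expected range from 6000 nM to 35000 nM.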

Compound 4, half-maximal inhibitory concentration: 17500 nM
Compound 4: middle estimate off by 1.2-fold (0.08 log units), on the low side; low and high end bracket the measured number.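

In this assay, trifluoromethoxy in place of trifluoromethyl on the core of compound 2 gives a 1.1-fold higher number from compound 2 to compound 4 (0.04 log units; within the scatter), a step that cannot be told from no change. Set beside the same change on the core of compound 1, this step shows that the exchange carries from one core to the other without a difference that can be resolved, on a place ortho to a large group as well: the same change on two cores in this assay, a 1.1-fold lower number (0.04 log units; within the scatter) from compound 1 to compound 3 and a 1.1-fold higher number (0.04 log units; within the scatter) from compound 2 to compound 4, 1.2-fold (0.09 log units) apart, within the scatter of two such steps It does not show that the change would carry over on other cores or in other assays, since the comparison rests on two pairs whose steps both lie within the scatter, so that a change of real size was never there to be transferred.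

From the compounds shown here alone, what stays open is how an amine, a carboxylic acid or a nitrile in place of trifluoromethyl on the aryl group would move the number in this assay. Also open, going by these compounds, is whether the exchange would behave alike with a longer chain between the sulfur and the aryl group, or with a group other than pentafluorosulfanyl on the aryl group of the amide.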